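The source may report more compounds than this note shows. Statements on the series, on what has been measured and on what is new or still open speak of the compounds shown alone.

Measured so far:
- compound 1, `N#CC1=C(N)N(c2ccc(S(N)(=O)=O)cc2)C2=C(C(=O)CCC2)C1c1ccccc1`: 30%
- compound 2, `N#CC1=C(N)N(c2ccc(S(N)(=O)=O)cc2)C2=C(C(=O)CCC2)C1c1ccc(O)cc1`: 95%
- compound 3, `COc1ccccc1C1C(C#N)=C(N)N(c2ccc(S(N)(=O)=O)cc2)C2=C1C(=O)CCC2`: 0%

In a functional assay on Ehrlich cells (Mus musculus) for antiproliferative activity, read by trypan blue exclusion, with a stated time of 2 h, tested at 25 ug/mL (a higher number here means a stronger effect of the compound at the concentration tested, a lower number a weaker effect), compound 1 stands second of the three, with compound 3 below it and compound 2 far above it. Compound 4, `COc1ccc(C2C(C#N)=C(N)N(c3ccc(S(N)(=O)=O)cc3)C3=C2C(=O)CCC3)cc1`, is not yet measured. It differs from compound 1 in one place: methoxy in place of hydrogen on an aromatic carbon.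

Among the measured compounds shown here, two measured steps bear on this change. The step of a number 65 percentage points higher from compound 1 to compound 2 (beyond the scatter) puts a hydroxy at the same place and raises the read-out strongly. The step of a number 30 percentage points lower from compound 1 to compound 3 (beyond the scatter) puts a methoxy on the same aromatic ring, though in compound 3 the ring reads as 2-methoxyphenyl rather than 4-methoxyphenyl, and lowers the read-out modestly. The step of a number 95 percentage points lower from compound 2 to compound 3 (beyond the scatter) shows how far apart those two substituted rings lie. Compound 4 shares the place of compound 2 but the group of compound 3, so an increase over compound 1 is expected, though a smaller one than a number 65 percentage points higher from compound 1 to compound 2 (beyond the scatter). For compound 4 the expected step is estimated as a number 20 percentage points higher from compound 1 to compound 4 (beyond the scatter), with a wide range. The estimate for compound 4 is 50%, between 10% and 85%.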

Compound 4, a percentage reported as activity, at one concentration (the size of the read-out at that concentration, not a potency): 50%
Compound 4: the middle estimate sits on the measured number at the digits printed; low and high end bracket the measured number.
By their numbers in this assay, from the lowest: compound 3; then compound 1; then compound 4; then compound 2.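

In this assay, methoxy as such does not lower the read-out: the change to 4-methoxyphenyl gives a number 20 percentage points higher from compound 1 to compound 4 (beyond the scatter), so the fall seen earlier with the 2-methoxyphenyl ring does not hold for every methoxy on this ring. Where the methoxy sits therefore matters a great deal, since moving to the 4-methoxyphenyl ring gives a number 50 percentage points higher from compound 3 to compound 4 (beyond the scatter). Adding a methyl to the oxygen of the hydroxy group costs much of the gain, with a number 45 percentage points lower from compound 2 to compound 4 (beyond the scatter), so the free hydroxy is clearly favoured over its methyl-capped form at this place.

No measurement on hand explains these differences. As far as these compounds go, it remains open whether an amine or a carboxylic acid at this place would match the hydroxy, and whether a longer chain on the oxygen, such as ethoxy, would lower the read-out further.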